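The compounds below may be only part of what the source reports. "The series", "measured", "known", "first", "only" and "open" are said of these compounds alone.

Measured compounds:
compound 1 `COc1ccc(-c2nc(SCC(=O)c3sc(-c4ccccc4)nc3C)[nH]c(=O)c2C#N)cc1OC`: 91800 nM
compound 2 `COc1ccc(-c2nc(SCC(=O)c3sc(-c4ccc(Cl)cc4)nc3C)[nH]c(=O)c2C#N)cc1OC`: "not determined" (no result reported)

In an ADME assay on HEK293 cells (Homo sapiens) for cytotoxicity, read by MTT assay, with a stated time of 48 h (a higher number here means a weaker inhibitor, a lower number a stronger inhibitor), compound 1 gives 91800 nM. Compound 2 has no number in this assay, so its standing cannot be read from any measurement. Compound 3 `Cc1nc(-c2ccc(Cl)cc2)sc1C(=O)CSc1nc(-c2cccc(Cl)c2)c(C#N)c(=O)[nH]1` differs from compound 2 in one place: 3-chlorophenyl in place of 3,4-dimethoxyphenyl on an aromatic carbon. For the measured compounds named here, no measured step between compounds shows how this change moves the reading in this assay, so no shift beyond the usual scatter is assumed in either direction. Going by the values given here, the only anchor is compound 1 at 91800 nM. Compound 3 is therefore expected to give 90000 nM in this assay, estimated between 30000 nM and 200000 nM.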

Compound 3, half-maximal inhibitory concentration: 30100 nM
Compound 3: middle estimate off by 3.0-fold (0.48 log units), on the high side, and the stated range covers the measured number.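

For the compounds shown here, with no number for compound 2 in this assay, no step from it to compound 3 can be read. As far as these compounds go, what replacing 3,4-dimethoxyphenyl with 3-chlorophenyl does to this reading stays open. No supporting evidence bears on this result.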